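Chloro in Place of Methyl: Expected Cytotoxicity of Compound 4

The source may hold more compounds than are shown below. What is called first, only, known or untested is meant among the compounds shown, and "the series" means these compounds.

Compound 2 `CCN(CC)CN1C(=O)/C(=N/NC(=S)Nc2ccc(C)cc2)c2ccccc21` was tested in an ADME assay on HeLa cells (Homo sapiens) for cytotoxicity (on this read-out lower numbers stand for higher toxicity in this test and higher numbers for lower toxicity in this test), and compound 2 gives only a limit of the assay, >= 20000 nM. Compound 1 `CCN(CC)CN1C(=O)/C(=N/NC(=S)Nc2ccc(Cl)cc2)c2ccccc21` differs from it by chloro in place of methyl on an aromatic carbon, and the step that the two limits leave unreadable from compound 2 to compound 1. Compound 1 likewise returns only a limit, >= 4000 nM. Compound 3 `CCN(CC)CN1C(=O)/C(=N/NC(=S)Nc2ccc(C)cc2)c2cc(Cl)ccc21` carries the other core, differing by chloro in place of hydrogen on an aromatic carbon, and compound 3 too reaches only a limit, >= 4000 nM. Among the three values stand the limit of >= 20000 nM in this assay, at which 1 of the 3 values shown sits, and (the limit of >= 4000 nM in this assay, at which 2 of the 3 values shown sit). Compound 4 `CCN(CC)CN1C(=O)/C(=N/NC(=S)Nc2ccc(Cl)cc2)c2cc(Cl)ccc21` stands to compound 3 as compound 1 stands to compound 2: chloro in place of methyl on an aromatic carbon, at a place described in the same words, so the change is the same. In this assay the step is expected to be a number no higher from compound 3 to compound 4 (the limit leaves the size open), an expectation resting on (the limit of >= 4000 nM in this assay, at which 2 of the 3 values shown sit). Compound 4 is therefore expected to show 4000 nM, between 2000 nM and 20000 nM, most likely reported only as a limit.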

Compound 4, minimum cytotoxic concentration: 100000 nM
Estimate against measurement, compound 4: 25-fold (1.40 log units) below; the whole stated range lies below it.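

Among these compounds, compound 1 and compound 3 are known only as limits in this assay, and no step from either of them to compound 4 can be read. The compounds shown leave open how large an effect either chloro replacement has on this read-out.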